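Swapping chloro for cyclopropyl on compound 2

This account rests on a few compounds, and the source may have more. Where it says the series, first, only, none or still open, it means among the compounds named here.

Measured so far in a functional assay on MCF7 cells (Homo sapiens) for antiproliferative activity, read by MTT assay, with a stated time of 48 h; a higher number here means a weaker inhibitor, a lower number a stronger inhibitor:
compound 1 `CC(=O)Nc1nc2ccc(-c3cnc(Cl)c(NS(=O)(=O)c4ccc(F)cc4)c3)cn2n1`: 19800 nM
compound 2 `COc1ncc(-c2ccc3nc(NC(C)=O)nn3c2)cc1NS(=O)(=O)c1ccc(Cl)cc1`: 2010 nM

Within the data shown here, only two numbers are available so far. Compound 2 holds the lower of them, with 2010 nM in this assay and a gap to compound 1 that lies beyond the scatter. It is therefore the stronger inhibitor of the pair.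

Compound 3 (`COc1ncc(-c2ccc3nc(NC(C)=O)nn3c2)cc1NS(=O)(=O)c1ccc(C2CC2)cc1`) keeps the shared core of compound 2 and carries cyclopropyl in place of chloro on an aromatic carbon. Cut one bond further out, the same difference reads 4-chlorophenyl to 4-cyclopropylphenyl. The new group sits para to a large group, as the chloro did.

Among the measured compounds shown here, no measured pair shows a change at this place alone, so the data offer no direct guide to its size. With the rest of compound 2 left as it is, no step beyond the scatter is expected in this assay in either direction. The estimated change is a 1.1-fold lower number from compound 2 to compound 3 (0.05 log units; within the scatter) and it carries a wide margin. Compound 3 is expected at 1800 nM (estimated range 600 nM to 5500 nM) in this assay.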

Compound 3, half-maximal inhibitory concentration: 1640 nM
For compound 3 the middle estimate is 1.1-fold (0.04 log units) above the measured one; low and high end bracket the measured number.
By their numbers in this assay, from the lowest: compounds 3 and 2 (each within the scatter of the next); then compound 1.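

In this assay, the first step read at this position, on an aromatic carbon para to a large group, runs a 1.2-fold lower number from compound 2 to compound 3 (0.09 log units; within the scatter) and lies within the scatter, so compound 2 and compound 3 cannot be told apart. The position thus accepts cyclopropyl, with 3 heavy atoms and a three-membered ring of carbon only, in place of chloro, with 1 heavy atom, without a step beyond the scatter in this read-out. No measurement among the data bears on why the two groups give such similar numbers.

Neither chloro nor cyclopropyl has a hydrogen-bond donor or acceptor, so the compounds shown leave open whether an amine, a carboxylic acid or a longer chain on this same carbon would also stay within the scatter of compound 2. Compound 1 differs from compound 2 in more than one place, which leaves open how much of the gap between them, if any, comes from the group at this position.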